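The compounds below may be only part of what the source reports. "The series", "measured", "known", "first", "only" and "open" are said of these compounds alone.

Compound 1 `CC(=O)Nc1ccc(OC(=S)Nc2ccc(Nc3ccc([N+](=O)[O-])cc3)cc2)cc1` is the reference point. In a physicochemical assay for acid dissociation, compound 1 gives 9.04, the second highest of the three measured numbers. Compound 2 `CC(=O)Nc1ccc(OC(=S)Nc2ccc(Sc3ccc([N+](=O)[O-])cc3)cc2)cc1` gives 8.99; that change is a number 0.05 log units lower from compound 1 to compound 2 (within the scatter). Compound 3 `O=[N+]([O-])c1ccc(Nc2ccc(NC(=S)Oc3ccc(O)cc3)cc2)cc1` gives 9.22; that change is a number 0.18 log units higher from compound 1 to compound 3 (within the scatter). Both measured steps stay within the scatter. Compound 4 `CC(=O)Nc1ccc(OC(=S)Nc2ccc(Nc3ccc(C(Cl)(Cl)Cl)cc3)cc2)cc1` differs from compound 1 by trichloromethyl in place of nitro on an aromatic carbon. Neither measured step touches the nitro group, so there is no direct guide; both known steps were small, and a small step is expected here as well. The step from compound 1 to compound 4 is estimated as a number 0.16 log units higher from compound 1 to compound 4 (within the scatter). Compound 4 is therefore expected to give 9.2, within a range from 8.8 to 9.7.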

Compound 4, acid dissociation constant: 9.01
Beside the measured number, compound 4's estimate is 0.19 log units above it; measured number inside the range.
By their numbers in this assay, from the lowest: compounds 2, 4, 1 and 3 (each within the scatter of the next).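

Trichloromethyl in place of nitro, on an aromatic carbon para to a large group, gives in this assay a number 0.03 log units lower from compound 1 to compound 4 (within the scatter) and so adds a first reading at this position, which neither earlier step touched. Like those two steps, this one stays within the scatter, so the two groups cannot be told apart here. No measurement shown bears on the reason for this result. At this position, only nitro and trichloromethyl are shown. On these data alone, how an amine or a carboxylic acid there would read in this assay remains open.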